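Anilino stilbene series: compound 3 to compound 4

The source may report more compounds than this note shows. Statements on the series, on what has been measured and on what is new or still open speak of the compounds shown alone.

The shared core carries a para-hydroxystyryl or arylamino-styryl arm on a quaternary carbon with a terpene-like chain. Compound 1 `C=C[C@@](C)(/C=C/c1ccc(O)cc1)CC/C=C(\C)CO` is the free phenol with a primary alcohol on the chain. In a functional assay on NALM-6 cells (Homo sapiens) for cytotoxicity, with a stated time of 72 h (on this read-out lower numbers stand for an effect already at smaller amounts and higher numbers for an effect only at larger amounts of compound), compound 1 reaches only the limit > 43400 nM. Compound 2 `CC(C)=CCC[C@](C)(/C=C/c1ccc(O)cc1)/C=C/c1cccc(F)c1` carries a second styryl arm bearing fluorine. In this assay compound 2 likewise stops at the limit > 43400 nM. Compound 3 `C=C[C@@](C)(/C=C/c1ccc(Nc2ccc(OC)cc2)cc1)CCC=C(C)C` replaces the phenol by a (4-methoxyphenyl)amino group. In this assay compound 3 also gives only the limit > 43400 nM, so it stands with the other two at the limit of > 43400 nM in this assay, at which 3 of the 3 values shown sit, and no ranking among the three is possible.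

Compound 4 `C=C[C@@](C)(/C=C/c1ccc(Nc2ccc(Cl)c(Cl)c2)cc1)CCC=C(C)C` differs from compound 3 in one place: 3,4-dichlorophenyl in place of 4-methoxyphenyl on a nitrogen on an aromatic ring. For the measured compounds named here, no measured step of this kind is at hand. Because compound 3 sits at the limit of > 43400 nM in this assay, at which 3 of the 3 values shown sit, compound 4 is expected to remain near that limit, with the step of an at least 1.0-fold lower number from compound 3 to compound 4 (0.03 log units; that floor lies within the scatter) estimated as no change beyond the scatter. For compound 4 the estimate in this assay is 40000 nM, within 8000 nM to 120000 nM.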

Compound 4, half-maximal effective concentration: > 43400 nM
Compound 4: a limit, no number; the forecaster's own chance of this, stated with the estimate: 65%; middle value at least 1.0-fold (0.03 log units) away from the limit.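

Compound 3 and compound 4 yield no readable step in this assay, as both results are limits and not numbers: the limit of > 43400 nM in this assay, at which 4 of the 4 values shown sit.

The compounds shown leave open how the four rank and which change on the shared core, if any, would give a measurable value in this assay.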